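From a carboxyethyl chain to a chlorobenzyl ether

The compounds below may be only part of what the source reports. "The series", "measured", "known", "first", "only" and "open" are said of these compounds alone.

Compound 3 `CCOC(=O)c1c(C)nc(-c2cccc(C#N)c2)n1OCCC(=O)O` reaches only a limit in a functional assay on a cell-free system (plasma, Oryctolagus cuniculus) for inhibition, with stated times of 5 min, 1 min and 6 min (a higher number here means a weaker inhibitor, a lower number a stronger inhibitor), at > 30000 nM. In this assay compound 1 `CCOC(=O)c1c(C)nc(-c2cccc(C#N)c2)n1O` gives 17600 nM, and compound 2 `C=CCOn1c(-c2cccc(C#N)c2)nc(C)c1C(=O)OCC` gives 5860 nM. Compound 4 `CCOC(=O)c1c(C)nc(-c2cccc(C#N)c2)n1OCc1ccc(Cl)cc1` differs from compound 3 by 4-chlorophenyl in place of carboxymethyl on a saturated chain carbon bound to an oxygen on an aromatic ring. For the measured compounds named here, two measured steps bear on this change: allyl in place of hydrogen gave a 3.0-fold lower number from compound 1 to compound 2 (0.48 log units; beyond the scatter), and carboxymethyl in place of vinyl gave an at least 5.1-fold higher number from compound 2 to compound 3 (0.70 log units; beyond the scatter). Read in reverse, the second step points to a lower number, at least modest in size. The expected step is an at least 10-fold lower number from compound 3 to compound 4 (1.00 log units; beyond the scatter). Compound 4 is estimated at 3000 nM, with an expected range of 700 nM to 14000 nM.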

Compound 4, half-maximal inhibitory concentration: 6830 nM
The estimate for compound 4 lay 2.3-fold (0.36 log units) below the measured number; low and high end bracket the measured number.
By their numbers in this assay, from the lowest: compounds 2 and 4 (each within the scatter of the next); then compound 1. At a limit, above all of these: compound 3.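

In this assay, 4-chlorobenzyl on this oxygen gives a 2.6-fold lower number from compound 1 to compound 4 (0.41 log units; beyond the scatter), so a group carrying an aromatic ring also lowers the number, and it gives a 1.2-fold higher number from compound 2 to compound 4 (0.07 log units; within the scatter), leaving it level with allyl. Exchanging carboxymethyl for 4-chlorophenyl gives an at least 4.3-fold lower number from compound 3 to compound 4 (0.64 log units; beyond the scatter). Compound 3 stands only at a limit of the assay, so that step has a floor and no fixed size: the limit of > 30000 nM in this assay, at which 1 of the 4 values shown sits. Going by these compounds, whether a methoxy group or fluorine in place of the chlorine would shift the number stays open. So does the effect of an amine at the end of a longer chain at this position.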